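Swapping the Heteroaryl Amide on a Sulfonyl Piperidine Scaffold

The compounds below may be only part of what the source reports. "The series", "measured", "known", "first", "only" and "open" are said of these compounds alone.

Measured compounds:
compound 1 `O=C(NCc1ccc(S(=O)(=O)N2CCCCC2)cc1)c1ccn2cncc2c1`: > 10000 nM
compound 2 `O=C(NCc1ccc(S(=O)(=O)c2ccccc2)cc1)c1cc2ccncc2s1`: 14 nM
compound 3 `O=C(NCc1ccc(S(=O)(=O)c2ccccc2)cc1)c1nc2cnccc2[nH]1`: 5400 nM

In a functional assay on A2780 cells (Homo sapiens) for inhibition, read by sulforhodamine B assay, with a stated time of 72 h (on this read-out higher numbers stand for weaker inhibition and lower numbers for stronger inhibition), compound 1 gives only a limit, > 10000 nM, so no number is known for it (the limit of > 10000 nM in this assay, at which 1 of the 3 values shown sits). Compound 2 gives 14 nM and compound 3 gives 5400 nM; the step of a 390-fold higher number from compound 2 to compound 3 (2.59 log units; beyond the scatter) shows that exchanging the heteroaryl group on the carbonyl carbon can move this assay a great deal. Compound 4 `O=C(NCc1ccc(S(=O)(=O)N2CCCCC2)cc1)c1ccc2nc[nH]c2c1` differs from compound 1 by a group of 9 heavy atoms (7 carbon, 2 nitrogen; one five-membered aromatic ring with 2 hetero atoms, one six-membered aromatic ring of carbon only) in place of a group of 9 heavy atoms (7 carbon, 2 nitrogen; one five-membered aromatic ring with 2 hetero atoms, one six-membered aromatic ring with 1 hetero atom), on a carbonyl carbon. Among the measured compounds shown here, the one measured step that resembles this change was large, but it sits in the sulfonyl phenyl series, not the sulfonyl piperidine of compound 1, and it gives no direction for this particular swap. The step that the limit leaves unreadable from compound 1 to compound 4 is therefore expected to be small or absent. Compound 4 is estimated at 12000 nM, between 2000 nM and 50000 nM.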

Compound 4, half-maximal inhibitory concentration: > 10000 nM
Compound 4: only a limit was reported; the forecaster's own chance of this, stated with the estimate: 60%; the middle value is on the limit's open side.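

Compound 4 gives > 10000 nM, a limit and not a number, as compound 1 also does, so the step between compound 1 and compound 4 cannot be read. The compounds shown leave open whether the 1H-benzimidazol-6-yl group changes inhibition at all in this assay on this scaffold.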